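Halogen swap on the N-phenyl ring of a quinolinone amide

The compounds below may be only part of what the source reports. "The series", "measured", "known", "first", "only" and "open" are said of these compounds alone.

Measured so far:
compound 1 `Cn1ccc2c(Oc3ccc(NC(=O)c4cn(-c5ccccc5)c5ccccc5c4=O)cc3F)ccnc21` gives 2170 nM
compound 2 `Cn1ccc2c(Oc3ccc(NC(=O)c4cn(-c5ccc(Cl)cc5)c5ccccc5c4=O)cc3F)ccnc21` gives 290 nM

Compound 2 stands at the lower of the two numbers in a functional assay on HepG2 cells (Homo sapiens) for inhibition, read by MTT assay, with a stated time of 72 h; on this read-out lower numbers stand for stronger inhibition and higher numbers for weaker inhibition; its nearest neighbour is compound 1, and the step of a 7.5-fold lower number from compound 1 to compound 2 (0.87 log units; beyond the scatter) separates them. Compound 3 `Cn1ccc2c(Oc3ccc(NC(=O)c4cn(-c5ccc(Br)cc5)c5ccccc5c4=O)cc3F)ccnc21` is not yet measured. It differs from compound 2 by bromo in place of chloro on an aromatic carbon. Within the data shown here, the only measured step at this position, a 7.5-fold lower number from compound 1 to compound 2 (0.87 log units; beyond the scatter), placed a halogen where hydrogen had been; the change from compound 2 to compound 3 keeps a halogen there and exchanges one for another. Among the measured compounds shown here, no measured step bears directly on that exchange. The expectation for compound 3 is therefore a number close to that of compound 2, with a step of a 1.2-fold lower number from compound 2 to compound 3 (0.06 log units; within the scatter) that is estimated to stay within the scatter. The estimate for compound 3 in this assay is 250 nM, with a range from 90 nM to 700 nM.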

Compound 3, half-maximal inhibitory concentration: 1260 nM
The estimate for compound 3 lay 5.0-fold (0.70 log units) below the measured number; measured number outside the range, above it.
By their numbers in this assay, from the lowest: compound 2; then compounds 3 and 1 (each within the scatter of the next).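

In this assay, exchanging one halogen for another at this position is not a neutral change: the step of a 4.3-fold higher number from compound 2 to compound 3 (0.64 log units; beyond the scatter) shows that the gain seen with chloro does not carry over to bromo at the same place. Bromo in place of hydrogen gives a 1.7-fold lower number from compound 1 to compound 3 (0.24 log units; within the scatter), so among the three compounds only compound 2, with its 4-chlorophenyl group, stands apart from the others. Nothing available here explains the difference between chloro and bromo.

The compounds shown leave open how fluoro, methyl, methoxy or trifluoromethyl would read at this place, and so whether chloro is an isolated case or part of a wider trend. They also leave open whether the gap between chloro and bromo would persist with an amine in place of the fluoro on the shared core.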